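From bromo to methoxy: an expectation for compound 3

The source may hold more compounds than are shown below. What is called first, only, known or untested is meant among the compounds shown, and "the series" means these compounds.

Measured in a functional assay on MDA-MB-231 cells (Homo sapiens) for inhibition, read by MTT assay, with a stated time of 5 days; on this read-out higher numbers stand for weaker inhibition and lower numbers for stronger inhibition:
- compound 1 `Cc1cc(Nc2nc(NCc3ccccc3Br)nc3[nH]ncc23)n[nH]1`: 3990 nM
- compound 2 `Cc1cc(Nc2nc(NCc3ccc(Br)cc3)nc3[nH]ncc23)n[nH]1`: 1860 nM

Among the measured compounds shown here, of these two, compound 2 has the lower number, and so the stronger inhibition, with compound 1 the only neighbour for comparison. Compound 3 `COc1ccc(CNc2nc(Nc3cc(C)[nH]n3)c3cn[nH]c3n2)cc1` keeps the rest of compound 2 and changes one group: methoxy in place of bromo on an aromatic carbon. In words, methoxy stands in place of bromo on an aromatic carbon.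

For the measured compounds named here, only one measured step bears on this change, and only indirectly. In a 2.1-fold lower number from compound 1 to compound 2 (0.33 log units; beyond the scatter), a modest step just beyond the scatter, 4-bromophenyl replaces 2-bromophenyl. That step moves the bromo but never replaces it, so the data hold no direct measure of the exchange of bromo for methoxy. A step of similar modest size therefore seems a fair expectation, and its direction is poorly defined, with a slight lean towards a higher number in this assay. The expected change is a 1.3-fold higher number from compound 2 to compound 3 (0.13 log units; within the scatter). For compound 3 the estimated value is 2500 nM, with an expected range from 1000 nM to 6000 nM.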

Compound 3, half-maximal inhibitory concentration: 1320 nM
Compound 3: the middle estimate sits 1.9-fold (0.28 log units) above what was measured, within the range that was stated.
By their numbers in this assay, from the lowest: compounds 3 and 2 (each within the scatter of the next); then compound 1.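

In this assay, among the compounds shown here, the exchange of bromo for methoxy on an aromatic carbon para to a large group gives a 1.4-fold lower number from compound 2 to compound 3 (0.15 log units; within the scatter) and so offers the first direct reading of this change. At this position the assay does not separate the two groups, although methoxy has 2 heavy atoms and 1 hydrogen-bond acceptor against 1 heavy atom and 0 hydrogen-bond acceptors for bromo. The wider comparison gives a 3.0-fold lower number from compound 1 to compound 3 (0.48 log units; beyond the scatter) as a modest step beyond the scatter, but it alters both the group and its place, so it cannot be assigned to either alone, and nothing shown accounts for the two groups reading alike.

The compounds shown leave open whether this position tolerates groups of other kinds, such as an amine, a carboxylic acid or a longer chain, as readily as it does bromo and methoxy. They also leave open how methoxy would read in the place that bromo holds in compound 1, which would show whether the difference between the two bromo compounds carries over to methoxy.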